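Cytotoxicity notes on the amide series, compound 3

The source may report more compounds than this note shows. Statements on the series, on what has been measured and on what is new or still open speak of the compounds shown alone.

Measured so far:
Compound 1, `COc1ccc(C(=O)Nc2cc3nc(C4CCCCC4)[nH]c3cc2N(C)C)cc1`, in an ADME assay on Vero cells (Chlorocebus sabaeus) for cytotoxicity, read by resazurin assay, with a stated time of 3 days (a higher number here means a weaker inhibitor, a lower number a stronger inhibitor), gives > 100 ug/mL, a limit of the assay.
Compound 2, `CCCCCC(=O)Nc1cc2nc(C3CCCCC3)[nH]c2cc1N(C)C`, in this assay gives > 100 ug/mL, likewise a limit of the assay.

Compound 2 therefore stands at the limit, not at a number. Within the data shown here, the one change measured, a step that the two limits leave unreadable from compound 1 to compound 2, cannot be sized, as both values sit at the limit of > 100 ug/mL in this assay, at which 2 of the 2 values shown sit.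

Compound 3 is `CN(C)c1cc2[nH]c(C3CCCCC3)nc2cc1NC(=O)c1ccco1`; relative to compound 2 the difference is furan-2-yl in place of pentyl on a carbonyl carbon. Among the measured compounds shown here, the only measured step at the carbonyl carbon is the unreadable one from compound 1 to compound 2, so it gives no size and no direction to carry over. For compound 3 the expected step is a step that the limit leaves unreadable from compound 2 to compound 3, no movement beyond the scatter, with the likelihood that this assay again reports only a limit. The estimate for compound 3 is 150 ug/mL, range 60 ug/mL to 400 ug/mL.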

Compound 3, half-maximal inhibitory concentration: > 100 ug/mL
Compound 3 ended at the assay's limit; the forecaster's own chance of this, stated with the estimate: 75%; the middle value is on the limit's open side.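

Compound 1, compound 2 and compound 3 all stand at a limit of the assay, so no new step among them can be read in this assay: the limit of > 100 ug/mL in this assay, at which 3 of the 3 values shown sit.

The compounds shown leave open whether any group on the carbonyl carbon gives a measurable value.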